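The compounds below may be only part of what the source reports. "The series", "measured", "known", "first", "only" and "open" are said of these compounds alone.

Measured so far:

Compound 1, `CC(=O)N1C=Cc2nc(NC(C)C)c(N3CCC(Oc4ccc(F)cc4F)CC3)nc2C1`, gives 96000 nM.
Compound 2, `CC(=O)N1C=Cc2nc(NC3CC3)c(N3CCC(Oc4ccc(F)cc4F)CC3)nc2C1`, gives 34000 nM.
Compound 3, `CC(=O)N1C=Cc2nc(N3CCC(Oc4ccc(F)cc4F)CC3)c(NC3CC3)nc2C1`, gives 43000 nM.

All three were tested in a functional assay on CHO-K1 cells for agonist activity at G-protein coupled receptor 6 (Homo sapiens), read by TR-FRET and cAMP accumulation, with a stated time of 20 h; a lower number here means that less compound is needed, a higher number that more compound is needed for the effect. Compound 1 and compound 2 share one core and differ only by isopropyl in place of cyclopropyl on a nitrogen on an aromatic ring. That change gave a 2.8-fold higher number from compound 2 to compound 1 (0.45 log units; beyond the scatter). Compound 3 carries the same atoms as compound 2 joined differently; the difference between the two cores is not broken down here, and their values in this assay lie within the usual scatter of each other.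

Compound 4, `CC(=O)N1C=Cc2nc(N3CCC(Oc4ccc(F)cc4F)CC3)c(NC(C)C)nc2C1`, is not yet measured. Among the compounds with values here, it differs from compound 3 by isopropyl in place of cyclopropyl on a nitrogen on an aromatic ring, the same change, at the same kind of place, as the one from compound 2 to compound 1. Since that earlier change produced a 2.8-fold higher number from compound 2 to compound 1 (0.45 log units; beyond the scatter), a step of similar size is expected here: compound 4 is estimated to show a 2.8-fold higher number from compound 3 to compound 4 (0.45 log units; beyond the scatter) in this assay. On that basis compound 4 is expected to give about 120000 nM, with a range from 60000 nM to 250000 nM.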

Compound 4, half-maximal effective concentration: 34000 nM
The estimate for compound 4 lay 3.5-fold (0.55 log units) above the measured number, outside the stated range (below it).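

Within the data shown here, putting isopropyl in place of cyclopropyl on a nitrogen on an aromatic ring did not behave the same way on both cores: in this assay the change gave a 1.3-fold lower number from compound 3 to compound 4 (0.10 log units; within the scatter) and so produced no step that stands out from the scatter on the core of compound 3. Set side by side, the two results disagree: the same change on two cores in this assay, a 2.8-fold higher number (0.45 log units; beyond the scatter) from compound 2 to compound 1 and a 1.3-fold lower number (0.10 log units; within the scatter) from compound 3 to compound 4, 3.6-fold (0.55 log units) apart, beyond the scatter of two such steps. The size of this change on one core is therefore no safe guide to its size on the other in this series, but two pairs do not show why the cores differ or how the change would act on any further core.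

The compounds shown leave open whether the gap between the two cores also holds for other groups on that nitrogen, such as a longer chain like butyl or a larger ring like cyclobutyl. They also leave open whether such a chain ending in an amine or a carboxylic acid would read alike on both cores.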